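The source may report more compounds than this note shows. Statements on the series, on what has been measured and on what is new or still open speak of the compounds shown alone.

Measured in a functional assay on DU-145 cells (Homo sapiens) for inhibition, read by trypan blue exclusion, with a stated time of 72 h; a higher number here means a weaker inhibitor, a lower number a stronger inhibitor:

- Compound 1 `Cn1c(=O)c(S(=O)(=O)c2ccc(F)cc2)cc2cnc(Nc3ccc4occc4c3)nc21` gives 5000 nM
- Compound 2 `Cn1c(=O)c(S(=O)(=O)c2ccc(F)cc2)cc2cnc(Nc3ccc4[nH]ncc4c3)nc21` gives 5000 nM
- Compound 3 `Cn1c(=O)c(S(=O)(=O)c2ccc(F)cc2F)cc2cnc(Nc3cnc4[nH]ccc4c3)nc21` gives 750 nM

Compound 3, at 750 nM, has the lowest number of the three, and its gap to each of the other two lies beyond the usual scatter. Compound 4 `Cn1c(=O)c(S(=O)(=O)c2ccc(F)cc2)cc2cnc(Nc3cnc4[nH]ccc4c3)nc21` has not yet been measured. It keeps all of compound 3 except for one atom: hydrogen in place of fluoro on an aromatic carbon. Hydrogen stands in place of fluoro on an aromatic carbon, turning 2,4-difluorophenyl into 4-fluorophenyl.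

Going by the values given here, no measured step isolates this change. Among the compounds with values here, the only step available, no change at the digits printed from compound 1 to compound 2 (within the scatter), swaps the group on nitrogen and leaves the fluoro pattern untouched, so it says little here. Compound 1 at 5000 nM and compound 2 at 5000 nM do carry the 4-fluorophenyl group, but they also differ from compound 3 in the group on nitrogen, so their higher numbers cannot be pinned on the fluoro alone. They suggest only a slight lean towards a higher number in this assay, and no step beyond the scatter is expected. The expected step is a 1.3-fold higher number from compound 3 to compound 4 (0.12 log units; within the scatter). For compound 4 the estimate is 1000 nM, with an expected range from 300 nM to 3500 nM.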

Compound 4, half-maximal inhibitory concentration: 500 nM
Compound 4: middle estimate off by 2.0-fold (0.30 log units), on the high side; the range from low to high includes it.
By their numbers in this assay, from the lowest: compounds 4 and 3 (each within the scatter of the next); then compounds 1 and 2 (each within the scatter of the next).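

In this assay, hydrogen in place of fluoro on the aromatic carbon ortho to the large group gives a 1.5-fold lower number from compound 3 to compound 4 (0.18 log units; within the scatter), so with this group on the nitrogen, the 2,4-difluorophenyl and 4-fluorophenyl forms cannot be told apart. With 4-fluorophenyl held fixed, changing the group on the nitrogen matters far more: replacing 1H-indazol-5-yl gives a 10-fold lower number from compound 2 to compound 4 (1.00 log units; beyond the scatter), and replacing 1-benzofuran-5-yl gives a 10-fold lower number from compound 1 to compound 4 (1.00 log units; beyond the scatter), so the higher numbers of these two earlier compounds go with the group on the nitrogen and not with the missing fluoro. Nothing available here accounts for either result.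

The compounds shown leave open whether the two phenyl forms would also match with 1H-indazol-5-yl or 1-benzofuran-5-yl on the nitrogen, since the fluoro swap is seen with only one such group. They also leave open whether a larger substituent on that same aromatic carbon, such as chloro, methyl or methoxy, would fit as readily as hydrogen and fluoro do.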